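A few compounds are considered here, and "the series" means these few. Any claim that something is new, unique, unknown or untested is made for them only; others in the source may bear on it.

Measured in a functional assay on MKN-45 cells (Homo sapiens) for inhibition, read by colorimetric assay and sulforhodamine B assay, with a stated time of 48 h; a higher number here means a weaker inhibitor of growth, a lower number a stronger inhibitor of growth:
- compound 1 `CCCCCCCCCCCC[C@@H](O)[C@H]1CC[C@H]([C@H](O)CCCCCCCCCCNC(=O)c2ccco2)O1` gives 100000 nM
- compound 2 `CCCCCCCCCCCC[C@@H](O)[C@H]1CC[C@H]([C@H](O)CCCCCCCCCCNC(=O)c2ccoc2)O1` gives 100000 nM
- compound 3 `CCCCCCCCCCCC[C@@H](O)[C@H]1CC[C@H]([C@H](O)CCCCCCCCCCNC(=O)c2cncs2)O1` gives 100000 nM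

Compound 3 stands level with compound 1 and compound 2 at these figures. Compound 4 `CCCCCCCCCCCC[C@@H](O)[C@H]1CC[C@H]([C@H](O)CCCCCCCCCCNC(=O)c2ccnn2C)O1` differs from compound 3 by one change, 1-methyl-1H-pyrazol-5-yl in place of 1,3-thiazol-5-yl on a carbonyl carbon with 1-methyl-1H-pyrazol-5-yl in place of 1,3-thiazol-5-yl on a carbonyl carbon. The closest measured steps are the other ring swaps at that carbonyl carbon: no change at the digits printed from compound 1 to compound 2 (within the scatter) and no change at the digits printed from compound 1 to compound 3 (within the scatter) and no change at the digits printed from compound 2 to compound 3 (within the scatter) all stay within the scatter. For the measured compounds named here, no measured compound carries 1-methyl-1H-pyrazol-5-yl, so this precedent is indirect. The expected step is no change at the digits printed from compound 3 to compound 4 (within the scatter) in this assay with no shift beyond the scatter and no favoured direction. Compound 4 is estimated at 100000 nM with an expected range from 30000 nM to 130000 nM for the coming measurement.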

Compound 4, concentration for 50% growth inhibition: 7410 nM
For compound 4 the middle estimate is 13-fold (1.13 log units) above the measured one, and the stated range ends above it.
By their numbers in this assay, from the lowest: compound 4; then compounds 1, 2 and 3 (each within the scatter of the next).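

In this assay the ring on the carbonyl carbon does affect the read-out, which the swaps among furan-2-yl, furan-3-yl and 1,3-thiazol-5-yl did not show: a 13-fold lower number from compound 3 to compound 4 (1.13 log units; beyond the scatter) and a 13-fold lower number from compound 2 to compound 4 (1.13 log units; beyond the scatter) and a 13-fold lower number from compound 1 to compound 4 (1.13 log units; beyond the scatter). So far, only 1-methyl-1H-pyrazol-5-yl gives a lower number among the four rings. Nothing available accounts for this difference.

As far as these compounds go, it remains open whether the methyl group is needed, which 1H-pyrazol-5-yl would test. A 1-ethyl-1H-pyrazol-5-yl or phenyl ring on the same carbonyl carbon would show how far the lower number extends.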